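The compounds below may be only part of what the source reports. "The series", "measured", "known", "first", "only" and "open" are said of these compounds alone.

Measured compounds in this series:
- compound 1, `Cc1nc(NCCNC(=O)C2CC2)nc2ccc(NC(=O)/C=C/c3ccc(OC(F)(F)F)cc3)cc12`: "not determined" (no result reported) in an ADME assay on microsomes from liver (Homo sapiens) for metabolic stability, with a stated time of 30 min; a higher number here means that more of the compound is left, a lower number that less of the compound is left
- compound 2, `COCC(=O)NC1CCN(c2nc(C)c3cc(NC(=O)/C=C/c4ccc(OC(F)(F)F)cc4)ccc3n2)CC1`: 58%

For the measured compounds named here, compound 2 is the only member with a number in this assay; compound 1 is a further entry without one, so compound 2 stands alone and no step between measured compounds can be drawn. The extent to which compound 2 is retained in this assay is therefore the single reference point.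

Compound 3, `Cc1nc(N2CCC(N3CCCS3(=O)=O)CC2)nc2ccc(NC(=O)/C=C/c3ccc(OC(F)(F)F)cc3)cc12`, is not yet measured. It differs from compound 2 in one place: a group of 7 heavy atoms (3 carbon, 1 nitrogen, 2 oxygen, 1 sulfur; one five-membered non-aromatic ring with 2 hetero atoms) in place of a group of 6 heavy atoms (3 carbon, 1 nitrogen, 2 oxygen; no ring), on a saturated ring carbon. Nothing measured in this set shows how such an exchange on that ring carbon plays out in this assay, so the direction of the step is open.

Going by the values given here, with no comparable pair to lean on, the expected step from compound 2 to compound 3 in this assay is small, a number 3 percentage points lower from compound 2 to compound 3 (within the scatter), not clearly beyond the usual scatter in either direction. For compound 3 the estimate in this assay is 55%, with a range from 35% to 75% reflecting the absence of any anchoring step in the series.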

Compound 3, percent of the compound remaining: 85%
Estimate against measurement, compound 3: 30 percentage points below, and the stated range ends below it.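

In this assay, for the compounds shown here, the saturated ring carbon three ring bonds from the ring nitrogen proves responsive to substitution: replacing the ((methoxymethyl)carbonyl)amino group with the five-membered non-aromatic ring with 2 hetero atoms gives a number 27 percentage points higher from compound 2 to compound 3 (beyond the scatter), the first readable step. The exchange changes several things at once, adding a ring and a sulfur atom and going from 1 hydrogen-bond donor to 0 hydrogen-bond donors, while both groups have 2 hydrogen-bond acceptors, and this single step does not separate these differences. No measurement available here bears on what lies behind the step.

Going by these compounds, it remains open whether the result depends on the ring, on the sulfur atom or on the absence of the amide hydrogen; an open-chain methylsulfonylamino group on the same ring carbon and a five-membered lactam with carbon in place of sulfur would divide these possibilities. On these data alone, the range of the position also remains open, since a primary amine, a carboxylic acid or a longer chain at that carbon could show whether the higher value extends beyond this one ring.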